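Aryl-triazole series: one cell-inhibition value, one analogue pending

The source may report more compounds than this note shows. Statements on the series, on what has been measured and on what is new or still open speak of the compounds shown alone.

Measured compounds:
compound 1 `O=C(Cn1cc(COc2ccc3c(c2)CCC3)nn1)Nc1ccc(Cl)cc1` — "not determined" (no result reported)
compound 2 `Cc1cccc(-n2cc(COc3ccc4c(c3)CCC4)nn2)c1` — 23.4%
compound 3 `O=[N+]([O-])c1cccc(-n2cc(COc3ccc4c(c3)CCC4)nn2)c1` — "not determined" (no result reported)

Only compound 2 carries a number in an ADME assay on HEK293 cells (Homo sapiens) for inhibition, read by MTT assay, with a stated time of 48 h, tested at 25 uM; on this read-out higher numbers stand for more inhibition at the one concentration tested (going by the name of the read-out) and lower numbers for less inhibition. Compound 1 and compound 3 were taken into the series but no result was reported for either, so compound 2 cannot be placed above or below any neighbour; its reading of 23.4% is the single point of reference and sits in the lower part of the scale.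

The next compound, compound 4 `Cc1ccc(-n2cc(COc3ccc4c(c3)CCC4)nn2)c(C)c1`, differs from compound 2 in one place: 2,4-dimethylphenyl in place of 3-methylphenyl on an aromatic nitrogen. Among the measured compounds shown here, no step between two measured compounds exists in this assay, so there is nothing measured to calibrate the effect of this change. An added methyl on the aryl group is a small change, and with no comparison in hand the expectation is for no step beyond the scatter, in either direction.

Accordingly the step from compound 2 to compound 4 in this assay is estimated at a number 1.6 percentage points higher from compound 2 to compound 4 (within the scatter). For the measured compounds named here, compound 4 is expected to give about 25% in this assay, with a plausible range from 8% to 45%, the width reflecting that only one measured value anchors the series.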

Compound 4, a percentage reported as inhibition, at one concentration (the size of the read-out at that concentration, not a potency): 19.9%
Beside the measured number, compound 4's estimate is 5.1 percentage points above it; low and high end bracket the measured number.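

In this assay, the series now has its first readable step: 2,4-dimethylphenyl in place of 3-methylphenyl on an aromatic nitrogen gives a number 3.5 percentage points lower from compound 2 to compound 4 (within the scatter). This gives the reading of compound 2 its first measured neighbour and shows that, on this aryl group, one added methyl does not separate the pair beyond the usual scatter, so the two compounds count as equal here and neither can be ranked above the other. No supporting data are available to explain the outcome of this change.

Among the compounds shown here, what remains open is whether this insensitivity extends beyond small carbon-only aryl groups, since the one readable pair says nothing about an amine, a carboxylic acid or a longer alkyl chain on the same aryl ring, any of which might yet produce a step beyond the scatter in this assay. On these data alone, it is equally open whether the amide-linked chlorophenyl side chain of compound 1 or the nitro group of compound 3 would depart from compound 2, as steps to these two compounds cannot be read.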